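Permeability notes: one pending analogue of compound 3

The compounds below may be only part of what the source reports. "The series", "measured", "known", "first", "only" and "open" are said of these compounds alone.

Measured so far in an ADME assay for permeability, using PAMPA, with a stated time of 30 min, at pH 7.4; on this read-out lower numbers stand for lower permeability and higher numbers for higher permeability:
- compound 1, `c1ccc(Oc2ccc3c(NCCCNCc4ccco4)ccnc3c2)cc1`, gives 317 10^-6 cm/s
- compound 2, `COc1ccc(Oc2ccc3c(NCCCNCc4ccco4)ccnc3c2)cc1`, gives 317 10^-6 cm/s
- compound 3, `FC(F)(F)c1cccc(Cc2ccc3c(NCCCNCc4ccco4)ccnc3c2)c1`, gives 23 10^-6 cm/s

Compound 3 stands lowest of the three numbers in this assay; compound 1 and compound 2 both sit far above it, each by a gap well beyond the scatter. For the measured compounds named here, the only single-point step among the measured compounds, no change at the digits printed from compound 1 to compound 2 (within the scatter), concerns a different part of the molecule and shows nothing beyond the scatter.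

Compound 4, `N#Cc1ccc(Cc2ccc3c(NCCCNCc4ccco4)ccnc3c2)cc1`, is the next compound to be measured. It differs from compound 3 as follows: 4-cyanophenyl in place of 3-(trifluoromethyl)phenyl on a saturated chain carbon bound to an aromatic carbon. Going by the values given here, no measured step covers this exchange, so the expectation rests on compound 3 alone, with the wide spread between compound 3 and the other two as a caution. The step of a 1.2-fold lower number from compound 3 to compound 4 (0.06 log units; within the scatter) is therefore expected to be small, in no firm direction, and within the scatter. Compound 4 is estimated at 20 10^-6 cm/s, with a range from 5 10^-6 cm/s to 80 10^-6 cm/s.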

Compound 4, apparent permeability in the ADME assay: 23 10^-6 cm/s
Estimate against measurement, compound 4: 1.2-fold (0.06 log units) below; the range from low to high includes it.
By their numbers in the ADME assay, from the lowest: compounds 3 and 4 (each within the scatter of the next); then compounds 1 and 2 (each within the scatter of the next).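

In the ADME assay, the exchange of 3-(trifluoromethyl)phenyl for 4-cyanophenyl on a saturated chain carbon bound to an aromatic carbon gives no change at the digits printed from compound 3 to compound 4 (within the scatter), so these two groups are interchangeable at this position on this read-out. In a physicochemical assay for solubility, with a stated time of 18 h, at pH 7.4 (a higher number here means a more soluble compound, a lower number a less soluble compound), compound 3 gives 4200 nM and compound 4 gives 4200 nM, the same printed number. In the ADME assay, the large steps lie elsewhere, at a 14-fold lower number from compound 2 to compound 4 (1.14 log units; beyond the scatter) and a 14-fold lower number from compound 1 to compound 4 (1.14 log units; beyond the scatter), with 4-cyanobenzyl in place of 4-methoxyphenoxy and of phenoxy on an aromatic carbon.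

No available data account for either the unchanged values or the large steps. Going by these compounds, those large steps change the whole group at once, so the share of the oxygen link against the ring substituents stays open, as does the outcome with an amine or a carboxylic acid on the ring.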